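The source may report more compounds than this note shows. Statements on the series, on what has been measured and on what is new or still open speak of the compounds shown alone.

Measured compounds:
- Compound 1 `Cc1ccc(NC(=O)N[C@H](C)c2ccccc2)cc1` gives 98%
- Compound 2 `CCCc1ccc(NC(=O)N[C@H](C)c2ccccc2)cc1` gives 31%
- Compound 3 `C[C@@H](NC(=O)Nc1ccc(C(F)(F)F)cc1)c1ccccc1` gives 89%

These three compounds share one core and differ only in the group on one aromatic carbon. In an ADME assay on the whole organism with Oryza sativa as the target, tested at 1 uM (a higher number here means a weaker effect of the compound at the concentration tested, a lower number a stronger effect), compound 3 stands second highest of the three numbers: its value sits within the scatter of compound 1, as the step of a number 9 percentage points lower from compound 1 to compound 3 (within the scatter) shows, while it lies far from compound 2, as the step of a number 58 percentage points higher from compound 2 to compound 3 (beyond the scatter) shows. The single large movement among the measured compounds is a number 67 percentage points lower from compound 1 to compound 2 (beyond the scatter).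

Compound 4 `C[C@@H](NC(=O)Nc1ccc(I)cc1)c1ccccc1` is not yet measured. It differs from compound 3 in one place: iodo in place of trifluoromethyl on an aromatic carbon. Among the compounds with values here, no measured step exchanges trifluoromethyl for iodo, so the two steps that touch compound 3 give only indirect guidance. Within the data shown here, replacing methyl by trifluoromethyl left the number where it was, and replacing propyl by trifluoromethyl raised it strongly; an iodo group at this position has no measured counterpart. Compound 4 is therefore expected to remain close to compound 3, with a step of a number 4 percentage points lower from compound 3 to compound 4 (within the scatter) that stays within the scatter, though a fall of the kind seen for compound 2 cannot be ruled out. The estimate for compound 4 in this assay is 85%, expected to fall between 55% and 100%.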

Compound 4, a percentage reported as activity, at one concentration (the size of the read-out at that concentration, not a potency): 91%
Beside the measured number, compound 4's estimate is 6 percentage points below it; the measured number falls inside the stated range.
By their numbers in this assay, from the lowest: compound 2; then compounds 3, 4 and 1 (each within the scatter of the next).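

In this assay, putting iodo in place of trifluoromethyl on this aromatic carbon swaps four heavy atoms for one, yet the result is a number 2 percentage points higher from compound 3 to compound 4 (within the scatter). The comparison with the methyl compound gives a number 7 percentage points lower from compound 1 to compound 4 (within the scatter), so methyl, trifluoromethyl and iodo all read alike at this position, while the propyl compound is the one exception, as a number 60 percentage points higher from compound 2 to compound 4 (beyond the scatter) shows. Nothing available explains why propyl stands apart from the other three groups.

The compounds shown leave open whether the much lower number belongs to propyl alone or would also appear with another saturated chain, such as butyl or a longer chain, at this position. Also open, as far as these compounds go, is how a group of a different kind on this aromatic carbon, such as an amine or a carboxylic acid, would read against the shared core.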